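A Cyclopentenone Takes the Place of a Pyrazinyl Amide

This account rests on a few compounds, and the source may have more. Where it says the series, first, only, none or still open, it means among the compounds named here.

Compound 1 `Cc1cnc(C(=O)N2C[C@@H](O[C@H](C)c3cc(C(F)(F)F)cc(C(F)(F)F)c3)[C@H](c3ccc(F)cc3)C2)cn1` carries a (5-methylpyrazin-2-yl)carbonyl on the ring nitrogen of the shared core, and in an assay on CHO cells for displacement of a labelled ligand from Substance-P receptor (Homo sapiens) (a lower number here means a stronger inhibitor, a higher number a weaker inhibitor), compound 1 gives 0.12 nM. Compound 2 `CCNC(=O)N1C[C@@H](O[C@H](C)c2cc(C(F)(F)F)cc(C(F)(F)F)c2)[C@H](c2ccc(F)cc2)C1` has an ethylamino on that carbonyl carbon instead, and in this assay compound 2 gives 0.1 nM; the step of a 1.2-fold lower number from compound 1 to compound 2 (0.08 log units; within the scatter). Compound 3 `C[C@@H](O[C@@H]1CN(C2=CC(=O)CC2)C[C@H]1c1ccccc1)c1cc(C(F)(F)F)cc(C(F)(F)F)c1`, which bears a phenyl rather than a 4-fluorophenyl and an oxocyclopentenyl on the ring nitrogen, gives 0.07 nM in this assay. Of the three numbers, compound 1 has the highest, yet its gaps to compound 2 and to compound 3 both fall within the scatter, so no ranking among them can be drawn.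

Compound 4 `CC1=C(N2C[C@@H](O[C@H](C)c3cc(C(F)(F)F)cc(C(F)(F)F)c3)[C@H](c3ccc(F)cc3)C2)CCC1=O` arises from compound 1 by 2-methyl-3-oxocyclopent-1-en-1-yl in place of (5-methylpyrazin-2-yl)carbonyl on an amine nitrogen in a ring. For the measured compounds named here, the one measured step that bears on this, a 1.2-fold lower number from compound 1 to compound 2 (0.08 log units; within the scatter), shows that exchanging the group on the ring nitrogen left the number essentially where it was; compound 3, with a related cyclopentenone, also sits close, though it differs from compound 4 in two places and no single step to it has been counted. The step of a 1.2-fold lower number from compound 1 to compound 4 (0.08 log units; within the scatter) is therefore expected to stay within the scatter, with no clear direction. Compound 4 is estimated at 0.1 nM, with a range from 0.04 nM to 0.3 nM.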

Compound 4, half-maximal inhibitory concentration: 0.13 nM
Estimate against measurement, compound 4: 1.3-fold (0.11 log units) below; measured number inside the range.
By their numbers in this assay, from the lowest: compounds 3, 2, 1 and 4 (each within the scatter of the next).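

Even the whole (5-methylpyrazin-2-yl)carbonyl can leave the amine nitrogen in the ring with the number in this assay staying level (a 1.1-fold higher number from compound 1 to compound 4 (0.03 log units; within the scatter)), and the same holds when 2-methyl-3-oxocyclopent-1-en-1-yl takes the place of ethylcarbamoyl (a 1.3-fold higher number from compound 2 to compound 4 (0.11 log units; within the scatter)). The earlier step had changed only what stood on a carbonyl carbon, with that carbonyl still attached to the ring nitrogen, whereas here a six-membered aromatic ring with 2 hetero atoms gives way to a five-membered non-aromatic ring of carbon only, with fewer hydrogen-bond acceptors and no difference beyond the scatter. No measurement shown offers an explanation for why these three quite different groups give matching numbers at this position.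

The compounds shown leave open how far this latitude extends, for instance whether a carboxylic acid or a primary amine in this place would keep the number at the same level. They also leave open what the methyl of the 2-methyl-3-oxocyclopent-1-en-1-yl contributes on its own, since no pair shown differs in that group alone.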